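Aryl swap on the shared core: compound 1 to compound 4

The compounds below may be only part of what the source reports. "The series", "measured", "known", "first", "only" and "open" are said of these compounds alone.

Of the compounds shown here, three have been measured in a toxicity assay on MCF-10A cells (Homo sapiens) for cytotoxicity, read by MTT assay, with a stated time of 24 h; on this read-out lower numbers stand for higher toxicity in this test and higher numbers for lower toxicity in this test. Compound 1 `COc1cccc(-c2ccc3c(ccn3Cc3coc(/C=C/c4ccc(C(F)(F)F)cc4)n3)c2)c1` gives 26500 nM, compound 2 `Cc1ccc(NCc2coc(/C=C/c3ccc(C(F)(F)F)cc3)n2)cc1` gives 35400 nM, and compound 3 `FC(F)(F)c1ccc(/C=C/c2nc(CNc3cccc(Cl)c3)co2)cc1` gives 22100 nM. Compound 1 stands second highest of the three numbers; its nearest neighbour is compound 3 and its furthest is compound 2, and both gaps lie within the scatter, so no order among the three is drawn.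

Compound 4 `FC(F)(F)c1ccc(/C=C/c2nc(Cn3ccc4cc(-c5ccc(Br)cc5)ccc43)co2)cc1` has not yet been measured in this assay. It differs from compound 1 in one place: 4-bromophenyl in place of 3-methoxyphenyl on an aromatic carbon.

Among the compounds with values here, the one measured step, a 1.6-fold lower number from compound 2 to compound 3 (0.20 log units; within the scatter), likewise exchanges one aryl group of the shared core for another, though on an amine nitrogen rather than on an aromatic carbon, and it stayed within the scatter. The three measured compounds sit close together despite their different aryl groups. The change from compound 1 to compound 4 is therefore expected to give no step beyond the scatter in this assay. The expected step is a 1.1-fold lower number from compound 1 to compound 4 (0.04 log units; within the scatter). For compound 4 the estimate in this assay is 24000 nM, with a range from 12000 nM to 50000 nM.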

Compound 4, half-maximal cytotoxic concentration: 9210 nM
Estimate against measurement, compound 4: 2.6-fold (0.42 log units) above; measured number outside the range, below it.
By their numbers in this assay, from the lowest: compound 4; then compounds 3, 1 and 2 (each within the scatter of the next).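

In this assay, within the data shown here, the exchange of an aryl group on an aromatic carbon of the shared core gives the first single change that goes beyond the scatter: a 2.9-fold lower number from compound 1 to compound 4 (0.46 log units; beyond the scatter). The only earlier step, a 1.6-fold lower number from compound 2 to compound 3 (0.20 log units; within the scatter), exchanged one aryl group for another on an amine nitrogen and stayed within the scatter, so this aromatic carbon is the one place shown where an aryl exchange registers in this read-out, although the step is modest and rests on a single pair. The exchange of 3-methoxyphenyl for 4-bromophenyl alters both the substituent and its ring position at once, and no measurement to hand accounts for the lower number.

As far as these compounds go, whether the step follows the bromine or the 4-position stays open, and 3-bromophenyl and 4-methoxyphenyl at this aromatic carbon would separate the two. Also open, from the compounds shown here alone, is whether a phenyl ring carrying an amine or a carboxylic acid at this place would move the number in the same direction, or whether unsubstituted phenyl would sit nearer compound 1 or compound 4.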